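A Sulfur-Bearing Side Chain on a Terpenoid Quinone

The source may hold more compounds than are shown below. What is called first, only, known or untested is meant among the compounds shown, and "the series" means these compounds.

Compound 1 `CC1=CCC[C@H]2[C@](C)(CC3=CC(=O)C=C(NCCC(=O)O)C3=O)[C@@H](C)CC[C@]12C` is a quinone carrying a (2-carboxyethyl)amino group on its core. In a functional assay on A549 cells (Homo sapiens) for cytotoxicity, read by MTT assay, with a stated time of 72 h (on this read-out higher numbers stand for weaker inhibition and lower numbers for stronger inhibition), compound 1 gives 26900 nM, the lowest of the two numbers measured here. Two simpler relatives share a different core. Compound 2 `CSCC[C@H](NC1=CC(=O)C=C(C(C)(C)C)C1=O)C(=O)O` carries a 1-carboxy-3-(methylsulfanyl)propyl group on its amine nitrogen; in this assay compound 2 reaches only a limit of the assay, > 200000 nM. Compound 3 `CC(C)C[C@H](NC1=CC(=O)C=C(C(C)(C)C)C1=O)C(=O)O` has an isopropyl in place of that (methylsulfanyl)methyl, and in this assay compound 3 gives 97900 nM. Within the data shown here, the one measured step between them, an at least 2.0-fold lower number from compound 2 to compound 3 (0.31 log units; beyond the scatter), shows the compound with the (methylsulfanyl)methyl chain as the weaker of the pair, and the limit of > 200000 nM in this assay, at which 1 of the 3 values shown sits, records that compound 2 sits at that limit.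

Compound 4 `CSCC[C@H](NC1=CC(=O)C=C(C[C@]2(C)[C@@H](C)CC[C@]3(C)C(C)=CCC[C@@H]23)C1=O)C(=O)O` keeps the core of compound 1 and changes only the chain on the nitrogen: 1-carboxy-3-(methylsulfanyl)propyl in place of 2-carboxyethyl on an amine nitrogen. Among the measured compounds shown here, no measured pair tests this exact swap, and the step from compound 2 to compound 3 concerns a different pair of chains on another core, so it offers only a hint that the entering chain leans toward weaker inhibition. The expected step is therefore a modest rise, a 2.2-fold higher number from compound 1 to compound 4 (0.35 log units; beyond the scatter). The estimated value of compound 4 in this assay is 60000 nM, expected to fall between 20000 nM and 200000 nM.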

Compound 4, half-maximal inhibitory concentration: 47300 nM
Compound 4: the middle estimate sits 1.3-fold (0.10 log units) above what was measured, and the stated range covers the measured number.
By their numbers in this assay, from the lowest: compounds 1 and 4 (each within the scatter of the next); then compound 3. At a limit, above all of these: compound 2.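

On the core of compound 1, the larger sulfur-bearing chain on the amine nitrogen moves the number only slightly in this assay, with a 1.8-fold higher number from compound 1 to compound 4 (0.25 log units; within the scatter), so this swap cannot be told apart from repeat-measurement noise. The earlier compounds had shown this chain only on a different core, where it sat on the weaker side of an at least 2.0-fold lower number from compound 2 to compound 3 (0.31 log units; beyond the scatter), whereas on the core of compound 1 it brings no change beyond the scatter, and compound 4 gives a real number, 47300 nM. On the other core, compound 2, with the same chain, stands at a limit of the assay rather than at a number: the limit of > 200000 nM in this assay, at which 1 of the 4 values shown sits.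

What the sulfur itself contributes on the core of compound 1 remains open, since the comparison of compound 2 with compound 3 has no counterpart on that core among the compounds shown. Also open, on these data alone, is how an amine or an amide in place of the carboxylic acid, or a longer chain on the nitrogen, would read in this assay.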